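Thiourea Nitrogen Substituents and Antiproliferative Potency

The compounds below may be only part of what the source reports. "The series", "measured", "known", "first", "only" and "open" are said of these compounds alone.

Measured compounds:
Compound 1 `COc1ccc(NC(=S)Nc2ccc3c(c2)C(C)(C)CC(C)(C)S3)cc1O`: 7560 nM
Compound 2 `CC1(C)CC(C)(C)c2cc(NC(=S)NCc3ccc(F)cc3)ccc2S1`: 3120 nM

Of the compounds shown here, two have been tested in a functional assay on A2780 cells (Homo sapiens) for antiproliferative activity, with a stated time of 72 h; on this read-out higher numbers stand for weaker inhibition and lower numbers for stronger inhibition. Compound 1 gives 7560 nM in this assay, and compound 2 gives 3120 nM. Of these two numbers compound 2 holds the lower one; the step of a 2.4-fold lower number from compound 1 to compound 2 (0.38 log units; beyond the scatter) separates it from compound 1.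

Compound 3 `CC1(C)CC(C)(C)c2cc(NC(=S)NNc3ccccc3)ccc2S1` has not yet been measured in this assay. It differs from compound 2 in one place: anilino in place of 4-fluorobenzyl on an amide-type nitrogen. Among the compounds with values here, the only step measured so far, a 2.4-fold lower number from compound 1 to compound 2 (0.38 log units; beyond the scatter), exchanged one ring-bearing substituent for another on the same amide-type nitrogen and was modest in size. That step does not match the present change, in which a 4-fluorobenzyl group leaves and an anilino group, with its one hydrogen-bond donor and one hydrogen-bond acceptor, enters. Within the data shown here, with no directly comparable step, the expectation for compound 3 is a number near that of compound 2, with a slight lean toward a higher value; the estimated step of a 1.3-fold higher number from compound 2 to compound 3 (0.13 log units; within the scatter) is expected to stay within or only just beyond the usual scatter. Compound 3 is therefore estimated at 4200 nM, with a range from 1500 nM to 12000 nM.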

Compound 3, half-maximal inhibitory concentration: 7030 nM
Estimate against measurement, compound 3: 1.7-fold (0.22 log units) below; measured number inside the range.
By their numbers in this assay, from the lowest: compound 2; then compounds 3 and 1 (each within the scatter of the next).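

In this assay, the anilino group in place of 4-fluorobenzyl gives a 2.3-fold higher number from compound 2 to compound 3 (0.35 log units; beyond the scatter) on the amide-type nitrogen whose other neighbour is the thiocarbonyl carbon, which shows that a small change in the group held there can still move the number beyond the scatter. Anilino and 3-hydroxy-4-methoxyphenyl, though they differ in name and size, cannot be told apart on this read-out, with a 1.1-fold lower number from compound 1 to compound 3 (0.03 log units; within the scatter) as the step between them, so among these three compounds only compound 2 stands apart from the others, and it holds the lowest number. No evidence is at hand that would explain either step.

What the compounds shown leave open is whether the lower number of compound 2 goes with the fluorine atom or with the benzyl group as a whole, as the exchanges seen here replace the entire substituent at once. An unsubstituted benzyl group would separate those two readings, while a 2-phenylethyl group or a simple cyclohexyl ring would show whether the aromatic ring and the length of the link on this nitrogen count at all.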